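The source may hold more compounds than are shown below. What is called first, only, known or untested is meant among the compounds shown, and "the series" means these compounds.

Within the data shown here, compound 1 `O=C(/C=C/c1ccc2c(c1)B(O)OC2)c1ccc(F)cc1` is one of two compounds measured in a functional assay on MDA-MB-231 cells (Homo sapiens) for cytotoxicity, read by MTT assay, with a stated time of 48 h (a higher number here means a weaker inhibitor, a lower number a stronger inhibitor), and in this assay compound 1 gives 1600 nM. Among the measured compounds shown here, compound 2 `O=C(/C=C/c1ccc2c(c1)B(O)OC2)c1ccc([N+](=O)[O-])cc1` is the only other compound with a number in this assay, and in this assay compound 2 gives 11200 nM. Compound 1 thus has the lowest of the two numbers shown, and the only measured step, a 7.0-fold higher number from compound 1 to compound 2 (0.85 log units; beyond the scatter), is a nitro in place of fluoro on an aromatic carbon. Compound 3 `O=C(/C=C/c1ccc2c(c1)B(O)OC2)c1cccc(F)c1` differs from compound 1 by 3-fluorophenyl in place of 4-fluorophenyl on a carbonyl carbon. For the measured compounds named here, no measured step moves the fluorine within the ring; the step from compound 1 to compound 2 swaps one group for another on the same carbon and does not bear on this change. With nothing in the numbers pointing either way, compound 3 is expected to sit close to compound 1, the estimated step being a 1.1-fold higher number from compound 1 to compound 3 (0.05 log units; within the scatter). Compound 3 is therefore estimated at 1800 nM, within a range of 700 nM to 5000 nM.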

Compound 3, half-maximal inhibitory concentration: 3000 nM
Beside the measured number, compound 3's estimate is 1.7-fold (0.22 log units) below it; measured number inside the range.
By their numbers in this assay, from the lowest: compounds 1 and 3 (each within the scatter of the next); then compound 2.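

In this assay, 3-fluorophenyl in place of 4-fluorophenyl on a carbonyl carbon gives a 1.9-fold higher number from compound 1 to compound 3 (0.27 log units; within the scatter), so this assay does not separate the two fluorophenyl isomers. At this position, the place of the fluorine on the ring therefore matters less in this pair than the nitro for fluoro swap, which gives a 7.0-fold higher number from compound 1 to compound 2 (0.85 log units; beyond the scatter) and is the only step shown beyond the scatter. No measurement at hand accounts for either result.

The compounds shown leave open whether 3-nitrophenyl would read like compound 2 or like compound 3, and how plain phenyl or a ring carrying an amine, a carboxylic acid or a methoxy group would read. Going by these compounds, all three also share one core, so how changes to that core would read remains open.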